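Benzyl ester in place of methyl ester on the shared core

A few compounds are considered here, and "the series" means these few. Any claim that something is new, unique, unknown or untested is made for them only; others in the source may bear on it.

Two compounds of this series have been run in a functional assay on cells (Oocyte) for inhibition of Voltage-dependent T-type calcium channel subunit alpha-1H (Homo sapiens), tested at 100 uM; a lower number here means less inhibition, a higher number more inhibition at the concentration tested (going by the name of the read-out). Compound 1 `COC(=O)CC1c2ccccc2N=C(N2CCN(C)CC2)N1c1ccccc1` gives 15% in this assay, and compound 2 `COC(=O)CC1c2ccccc2N=C(N2CCN(C)CC2)N1C1CCCCC1` gives 3%. For the measured compounds named here, compound 1 thus holds the higher of the two numbers; the one step recorded, a number 12 percentage points lower from compound 1 to compound 2 (beyond the scatter), comes from cyclohexyl in place of phenyl on an amine nitrogen in a ring and is modest.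

Compound 3 `CN1CCN(C2=Nc3ccccc3C(CC(=O)OCc3ccccc3)N2c2ccccc2)CC1` differs from compound 1 elsewhere: phenyl in place of hydrogen on a saturated chain carbon bound to an oxygen next to a carbonyl group. Read one bond further out, this is methoxycarbonyl to benzyloxycarbonyl. Going by the values given here, no measured step touches the ester end of the molecule, so the single recorded step on the amine nitrogen in a ring says little about this change; it shows only that a change on the core moved this assay by a modest amount. With nothing closer to go on, the step of a number 2 percentage points higher from compound 1 to compound 3 (within the scatter) is expected to stay within the scatter, in no firm direction. Compound 3 is therefore estimated at 17% in this assay, with a range from 2% to 35%.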

Compound 3, a percentage reported as inhibition, at one concentration (the size of the read-out at that concentration, not a potency): 32.7%
Estimate against measurement, compound 3: 15.7 percentage points below; measured number inside the range.
By their numbers in this assay, from the lowest: compound 2; then compound 1; then compound 3.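

In this assay the ester end of the molecule now has a measured step: methoxycarbonyl to benzyloxycarbonyl gives a number 17.7 percentage points higher from compound 1 to compound 3 (beyond the scatter), so phenyl in place of hydrogen on a saturated chain carbon bound to an oxygen next to a carbonyl group does move this read-out. For the compounds shown here, the only earlier step, on an amine nitrogen in a ring, went the other way, a number 12 percentage points lower from compound 1 to compound 2 (beyond the scatter), so the shared core now shows one change that lowers the number and one, at a different place, that raises it. Nothing at hand bears on why the benzyl ester raises the number.

On these data alone, whether the rise belongs to the phenyl ring itself or would also come with other esters remains open: an ethyl ester, a cyclohexylmethyl ester or a phenethyl ester would separate these readings, and a carboxylic acid or an amide at the same end would show how much the ester matters. As far as these compounds go, the benzyl ester also stands here only with phenyl on the amine nitrogen in a ring, so its pairing with cyclohexyl remains open.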